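A few compounds are considered here, and "the series" means these few. Any claim that something is new, unique, unknown or untested is made for them only; others in the source may bear on it.

Measured compounds:
compound 1, `Cc1ccc(C)c(C(=O)NC(CCN(C)C)c2ccc(Cl)cc2)c1` — 2880 nM
compound 2, `CN(C)CCC(OC(=O)NCc1ccccc1)c1ccc(Cl)cc1` — 2140 nM

In an assay on NIH3T3 cells with Urotensin-2 receptor (Homo sapiens) as the target (a lower number here means that less compound is needed, a higher number that more compound is needed for the effect), compound 1 gives 2880 nM, while compound 2 gives 2140 nM; the two numbers lie within the scatter of each other, so neither can be set apart from the other in this assay. Compound 3, `CN(C)CCC(NC(=O)NCc1ccccc1)c1ccc(Cl)cc1`, has not yet been measured. It differs from compound 1 by benzylamino in place of 2,5-dimethylphenyl on a carbonyl carbon, turning the amide of compound 1 into a urea. Compound 2 carries the same benzylamino group on its carbonyl carbon and gives 2140 nM, and the number for compound 3 is therefore expected to fall close to that. The step of a 1.4-fold lower number from compound 1 to compound 3 (0.16 log units; within the scatter) is accordingly expected to stay within the scatter, with no direction claimed. For compound 3 the estimate in this assay is 2000 nM, with a range of 800 nM to 5000 nM.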

Compound 3, half-maximal effective concentration: 2000 nM
For compound 3 middle estimate and measured number coincide at the digits printed; measured number inside the range.
By their numbers in this assay, from the lowest: compounds 3, 2 and 1 (each within the scatter of the next).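

In this assay, benzylamino in place of 2,5-dimethylphenyl on a carbonyl carbon gives a 1.4-fold lower number from compound 1 to compound 3 (0.16 log units; within the scatter), so turning the amide into a urea, with a hydrogen-bond donor entering, yields a number that cannot be set apart from that of compound 1. With benzylamino held fixed, the carbamate compound 2 gives 2140 nM and the urea compound 3 gives 2000 nM, two numbers within the scatter of each other. No measurement of any property bears on this result.

The compounds shown leave open whether any group on this carbonyl carbon can move the number beyond the scatter, for instance phenethylamino or cyclohexylamino in place of benzylamino. They also leave open how the number responds to replacing the dimethylamino group with a pyrrolidine, or the chlorine with a methoxy group.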